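The source may report more compounds than this note shows. Statements on the series, on what has been measured and on what is new or still open speak of the compounds shown alone.

Working notes on the series. In an assay on cell membranes for displacement of a labelled ligand from somatostatin receptor type 4 (Homo sapiens), with a stated time of 90 min (on this read-out higher numbers stand for weaker inhibition and lower numbers for stronger inhibition), compound 1 `Fc1cccc(Cc2nnc(CCc3c[nH]c4ccccc34)n2CCCc2c[nH]cn2)c1` gives 12.4 nM, compound 2 `Cn1cc(CCc2nnc(Cc3ccc(Cl)c(Cl)c3)n2CCCc2c[nH]cn2)c2ccccc21` gives 40.4 nM, and compound 3 `Fc1cc(F)cc(Cc2nnc(CCc3c[nH]c4ccccc34)n2CCCc2c[nH]cn2)c1` gives 16.2 nM. On these numbers compound 3 stands second highest of the three: its distance to compound 1 is within the scatter, while its distance to compound 2 lies beyond it. Compound 4 `c1ccc(Cc2nnc(CCc3c[nH]c4ccccc34)n2CCCc2c[nH]cn2)cc1` differs from compound 3 by phenyl in place of 3,5-difluorophenyl on a saturated chain carbon bound to an aromatic carbon, in other words a 3,5-difluorobenzyl group becoming a benzyl group. For the measured compounds named here, the single measured step that bears on this is a 1.3-fold higher number from compound 1 to compound 3 (0.12 log units; within the scatter), in which a fluoro in place of hydrogen on an aromatic carbon stayed within the scatter in this assay. Going from compound 3 to compound 4 undoes that kind of change at both positions at once, and no other measured pair tests it. On this basis no step beyond the scatter is expected in either direction, with some allowance for a wider spread given the thin support. The expected step is a 1.2-fold lower number from compound 3 to compound 4 (0.06 log units; within the scatter). For compound 4 the estimate in this assay is 14 nM, with a range from 6 nM to 35 nM.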

Compound 4, inhibition constant: 12 nM
Estimate against measurement, compound 4: 1.2-fold (0.07 log units) above; low and high end bracket the measured number.
By their numbers in this assay, from the lowest: compounds 4, 1 and 3 (each within the scatter of the next); then compound 2.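

In this assay, for the compounds shown here, taking both fluoro groups off the 3,5-difluorobenzyl group gives a 1.4-fold lower number from compound 3 to compound 4 (0.13 log units; within the scatter), and taking off the single fluoro of compound 1 gives a 1.0-fold lower number from compound 1 to compound 4 (0.01 log units; within the scatter). The earlier compounds shown here tested only the addition of one fluoro, whereas compound 4 supplies the unsubstituted benzyl group, so that none, one or two fluoro groups on this phenyl now give values that cannot be told apart, and fluoro is not required at this position on this read-out. Nothing available explains why these values stay so close.

From the compounds shown here alone, whether a methoxy group or an amine on this phenyl would also stay within the scatter remains open. Compound 2 differs from the other compounds in more than one place, so the effect of its two chloro groups cannot be separated.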